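The source may hold more compounds than are shown below. What is called first, only, known or untested is meant among the compounds shown, and "the series" means these compounds.

Measured in an assay on isolated protein for inhibition of NADPH oxidase 4 (Homo sapiens), read by chemiluminescence, in the presence of a further agent that is not named here; a higher number here means a weaker inhibitor, a lower number a stronger inhibitor:
compound 1 `CN1C(=S)N(C2CCCCC2)C(=O)/C1=C\c1ccc(N(C)CCCO)cc1` gives 1190 nM
compound 2 `COc1cc(N(C)CCCO)ccc1/C=C1\C(=O)N(C2CCCCC2)C(=S)N1C` gives 2170 nM
compound 3 `CCN(CC)c1ccc(/C=C2\C(=O)N(C3CCCCC3)C(=S)N2C)c(O)c1` gives 2350 nM

Compound 3 has the highest of these three numbers, yet its distances to compound 2 and to compound 1 both lie within the usual scatter, so the three cannot be told apart. Compound 4 `CN1C(=S)N(C2CCCCC2)C(=O)/C1=C\c1ccc(N(C)CCCO)cc1O` is compound 3 with one change: (3-hydroxypropyl)(methyl)amino in place of diethylamino on an aromatic carbon. Going by the values given here, no measured step makes exactly this change. Among the compounds with values here, the only measured step, a 1.8-fold higher number from compound 1 to compound 2 (0.26 log units; within the scatter), concerns a different group and lies within the scatter. Compound 1 already carries the entering group, without the hydroxy group, and gives 1190 nM, within the scatter of compound 3. The expected step of a 1.2-fold lower number from compound 3 to compound 4 (0.07 log units; within the scatter) is therefore small, not beyond the scatter. Compound 4 is estimated at 2000 nM, with a range from 900 nM to 4500 nM.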

Compound 4, half-maximal inhibitory concentration: 2500 nM
Estimate against measurement, compound 4: 1.3-fold (0.10 log units) below, within the range that was stated.
By their numbers in this assay, from the lowest: compounds 1, 2, 3 and 4 (each within the scatter of the next, the first and the last beyond it).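

In this assay, (3-hydroxypropyl)(methyl)amino and diethylamino at this place, meta to a hydroxy group, cannot be told apart (a 1.1-fold higher number from compound 3 to compound 4 (0.03 log units; within the scatter)). Hydrogen in place of methyl on the oxygen on the aromatic ring also makes no readable difference (a 1.2-fold higher number from compound 2 to compound 4 (0.06 log units; within the scatter)). Going by these compounds alone, the gain of a hydroxy group on the aromatic ring is the one new step beyond the scatter, and it is modest (a 2.1-fold higher number from compound 1 to compound 4 (0.32 log units; beyond the scatter)).

No measurement here bears on why these steps come out this way. As far as these compounds go, whether an amine or a carboxylic acid in place of the chain's hydroxy group, or a longer chain, would shift the number remains open.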